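This account rests on a few compounds, and the source may have more. Where it says the series, first, only, none or still open, it means among the compounds named here.

Measured compounds and their values in a functional assay on HEK293 cells for agonist activity at growth hormone secretagogue receptor type 1 (Homo sapiens), read by HTRF and inositol phosphate accumulation, with a stated time of 90 min, in the presence of a further agent that is not named here; a lower number here means a smaller maximal response, a higher number a larger maximal response:

Compound 1, `Cc1ccc2[nH]c(C(=O)N[C@H]3CCN(C(=O)c4cccnc4)C[C@@H]3C(=O)NCCN(C)C)cc2c1`: 91%
Compound 2, `O=C(N[C@H]1CN(S(=O)(=O)c2ccccc2)C[C@@H]1C(=O)N[C@H]1CCCNC1)c1cc(-c2ccccc2Cl)on1`: 98%
Compound 3, `CN(C(=O)c1cc(-c2ccccc2Cl)on1)[C@H]1CN(S(=O)(=O)c2ccccc2)C[C@@H]1C(=O)N[C@H]1CCCNC1`: 103%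

Compound 3 and compound 2 lie within the usual scatter of each other in this assay, so no order between the two can be claimed; compound 1 lies beyond the scatter, lower than compound 3.

The unmeasured compound 4, `CN(C(=O)[C@H]1CN(S(=O)(=O)c2ccccc2)C[C@@H]1N(C)C(=O)c1cc(-c2ccccc2Cl)on1)[C@H]1CCCNC1`, differs from compound 3 in one place: methyl in place of hydrogen on an amide-type nitrogen. The change is thus the same kind of change already made once in this series, on the other amide-type nitrogen, in going from compound 2 to compound 3, where it gave a number 5 percentage points higher from compound 2 to compound 3 (within the scatter) in this assay. That single step is the only one that bears on the present one, and it stayed within the scatter. Within the data shown here, on that basis the step expected for compound 4 in this assay is a number 3 percentage points lower from compound 3 to compound 4 (within the scatter), that is, no change that would clearly exceed the scatter in either direction; with only one precedent, a second methyl could still behave differently, so the range is kept wide. Compound 4 is therefore estimated at 100% in this assay, with a range from 85% to 115%.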

Compound 4, largest response reached (Emax), in percent of the reference or control that the assay uses in the growth hormone secretagogue receptor type 1 assay: 95%
For compound 4 the middle estimate is 5 percentage points above the measured one; the measured number falls inside the stated range.
By their numbers in the growth hormone secretagogue receptor type 1 assay, from the lowest: compounds 1, 4, 2 and 3 (each within the scatter of the next, the first and the last beyond it).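

In the growth hormone secretagogue receptor type 1 assay, methyl in place of hydrogen on the amide-type nitrogen whose other neighbours are a carbonyl carbon and a saturated ring carbon gives a number 8 percentage points lower from compound 3 to compound 4 (within the scatter), so this second amide hydrogen, like the first one replaced in a number 5 percentage points higher from compound 2 to compound 3 (within the scatter), can give way to methyl without a step beyond the scatter in the largest response reached. The same change can now also be read for solubility: in a physicochemical assay for solubility, at pH 7.4 (a lower number here means a less soluble compound, a higher number a more soluble compound), compound 3 gives 655000 nM and compound 4 gives 553000 nM, two values within the usual scatter of each other, so methyl at this position leaves no readable mark on either read-out. Nothing available offers an explanation for these readings.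

The compounds shown leave open whether an ethyl group, a longer chain or a chain ending in an amine would be accepted on this same nitrogen as methyl is, in either read-out. They also leave open how the concentration needed for the response moves with this change, since only the largest response reached is given here.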